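Chain extension from compound 3 to compound 4

This account rests on a few compounds, and the source may have more. Where it says the series, first, only, none or still open, it means among the compounds named here.

Measured in an ADME assay on MT4 cells (Homo sapiens) for cytotoxicity, read by MTT assay; a lower number here means that less compound is tolerated, a higher number that more compound is tolerated (values in the right-hand column):
compound 1 `CCCCCCC1C(=O)N(O)C(=O)c2ccccc21` – 4400 nM
compound 2 `CCCC1C(=O)N(O)C(=O)c2ccccc21` – 25400 nM
compound 3 `CC1C(=O)N(O)C(=O)c2ccccc21` – 250000 nM

Compound 3 (250000 nM) has the highest number of the three. Compound 4 `CCC1C(=O)N(O)C(=O)c2ccccc21` is not yet measured in this assay and differs from compound 3 by methyl in place of hydrogen on a saturated chain carbon bound to a saturated ring carbon.

Among the measured compounds shown here, two measured steps bear most directly on this change. The closest is a 9.8-fold higher number from compound 2 to compound 3 (0.99 log units; beyond the scatter), since the ethyl difference there contains the methyl added here. The next is a 5.8-fold higher number from compound 1 to compound 2 (0.76 log units; beyond the scatter), which runs the same way. For the measured compounds named here, no measured compound goes against this trend, though only three compounds define it. Going by the values given here, a lower number is therefore expected, with a step smaller than the one separating compound 2 and compound 3.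

The expected step is a 3.1-fold lower number from compound 3 to compound 4 (0.49 log units; beyond the scatter). For compound 4 the estimate is 80000 nM, with an expected range of 40000 nM to 160000 nM.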

Compound 4, half-maximal cytotoxic concentration: 250000 nM
The estimate for compound 4 lay 3.1-fold (0.49 log units) below the measured number; measured number outside the range, above it.
By their numbers in this assay, from the lowest: compound 1; then compound 2; then compounds 3 and 4 (each within the scatter of the next).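

In this assay, methyl in place of hydrogen on a saturated chain carbon bound to a saturated ring carbon gives no change at the digits printed from compound 3 to compound 4 (within the scatter), so the methyl to ethyl change does not register at this position. The chain trend is therefore not even across the series: compound 3 and compound 4 go against any stepwise fall, and the separation appears only with the longer chains, as a 9.8-fold higher number from compound 2 to compound 4 (0.99 log units; beyond the scatter) and a 57-fold higher number from compound 1 to compound 4 (1.75 log units; beyond the scatter) show. No supporting data bear on why the short-chain end of the series is flat.

Still open, as far as these compounds go, is how a branched chain such as isopropyl, or a chain ending in an amine or a carboxylic acid, would behave at this position in this assay. Also open, from the compounds shown here alone, is whether a bare hydrogen there would match methyl and ethyl.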